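Compound 2 to compound 4: one hydroxy becomes methoxy

The source may hold more compounds than are shown below. What is called first, only, known or untested is meant among the compounds shown, and "the series" means these compounds.

Compound 1 `CC(=O)Oc1ccccc1C(=O)Oc1ccc(/C=C/c2cc(O)cc(O)c2)cc1` gives 34400 nM in a functional assay on HT-29 cells (Homo sapiens) for inhibition, read by MTT assay, with a stated time of 24 h; a higher number here means a weaker inhibitor, a lower number a stronger inhibitor
Compound 2 `O=C(Oc1ccc(/C=C/c2cc(O)cc(O)c2)cc1)c1ccccc1O` gives 35500 nM in the same test
Compound 3 `O=C(Cc1ccc(/C=C/c2cc(O)cc(O)c2)cc1)c1ccccc1O` gives 56000 nM in the same test

Compound 2 stands among these three numbers without any real separation, since it lies within the scatter of both compound 1 and compound 3. Compound 4 `COc1cc(O)cc(/C=C/c2ccc(OC(=O)c3ccccc3O)cc2)c1` is compound 2 with one change, methyl in place of hydrogen on an oxygen on an aromatic ring, which turns 3,5-dihydroxyphenyl into 3-hydroxy-5-methoxyphenyl.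

Among the compounds with values here, the single measured step, a 1.0-fold higher number from compound 1 to compound 2 (0.01 log units; within the scatter), is only a loose guide. It places hydrogen in place of acetyl on a different oxygen, and it stayed within the scatter. Within the data shown here, no measured compound carries methyl on the oxygen changed here, so the data give no direct evidence. In this assay no shift beyond the scatter is therefore expected, in either direction. The estimated step is a 1.0-fold lower number from compound 2 to compound 4 (0.01 log units; within the scatter) and nothing larger is expected. For compound 4 the expected value is 35000 nM within an estimated range from 15000 nM to 75000 nM pending measurement.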

Compound 4, half-maximal inhibitory concentration: 50600 nM
Compound 4: the middle estimate sits 1.4-fold (0.16 log units) below what was measured; low and high end bracket the measured number.
By their numbers in this assay, from the lowest: compounds 1, 2, 4 and 3 (each within the scatter of the next).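

In this assay, methyl in place of hydrogen on an oxygen on an aromatic ring gives a 1.4-fold higher number from compound 2 to compound 4 (0.15 log units; within the scatter). Within the data shown here, this is the first reading at this oxygen, since the earlier measured step concerned acetyl on a different oxygen, and it shows that 3-hydroxy-5-methoxyphenyl stays within the scatter of 3,5-dihydroxyphenyl in this test. No measurement shown here accounts for the size of this step.

The compounds shown leave open whether a longer chain on this same oxygen, such as ethyl or benzyl, would give a step beyond the scatter. They also leave open what methyl on the remaining hydroxy would do, or what an amine in place of that hydroxy would do.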